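Chloroethenyl to 2-methylprop-1-en-1-yl amide on a second core

The source may report more compounds than this note shows. Statements on the series, on what has been measured and on what is new or still open speak of the compounds shown alone.

Compound 1 `C=C(Cl)C(=O)Nc1cc(Nc2nc3c(c(-c4cn(C)c5ccc(F)cc45)n2)CSCC3)c(OC)cc1N(C)CCN(C)C` and compound 2 `COc1cc(N(C)CCN(C)C)c(NC(=O)C=C(C)C)cc1Nc1nc2c(c(-c3cn(C)c4ccc(F)cc34)n1)CSCC2` share one core and differ only at the amide: 2-methylprop-1-en-1-yl in place of 1-chloroethenyl on a carbonyl carbon. In a functional assay on A549 cells (Homo sapiens) for inhibition, read by MTT assay, with a stated time of 72 h (on this read-out higher numbers stand for weaker inhibition and lower numbers for stronger inhibition), compound 1 gives 864 nM, and compound 2 gives 902 nM. The step of a 1.0-fold higher number from compound 1 to compound 2 (0.02 log units; within the scatter) is flat; on this core the two amides are not told apart by the read-out.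

Compound 3 `C=C(Cl)C(=O)Nc1cc(Nc2nc3c(c(-c4cn(C)c5ccccc45)n2)CS(=O)(=O)CC3)c(OC)cc1N(C)CCN(C)C` carries the 1-chloroethenyl amide on a different core; the difference between the core of compound 1 and the core of compound 3 is not broken down here. In this assay compound 3 gives 881 nM, a number that sits within the scatter of both compound 1 and compound 2, so the core change itself has not moved the read-out by an amount that can be read.

Compound 4 `COc1cc(N(C)CCN(C)C)c(NC(=O)C=C(C)C)cc1Nc1nc2c(c(-c3cn(C)c4ccccc34)n1)CS(=O)(=O)CC2` stands to compound 3 as compound 2 stands to compound 1: 2-methylprop-1-en-1-yl in place of 1-chloroethenyl on a carbonyl carbon. The place lines of the two changes read the same word for word, so this is the same change, now made on the core of compound 3. The step from compound 3 to compound 4 is expected to be about as flat as the earlier one, a 1.0-fold higher number from compound 3 to compound 4 (0.01 log units; within the scatter), because of a 1.0-fold higher number from compound 1 to compound 2 (0.02 log units; within the scatter) on the other core. Compound 4 is therefore estimated at 900 nM in this assay, with a range from 450 nM to 1800 nM that covers the usual scatter around compound 3 and the lack of any second example of this change on this core.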

Compound 4, half-maximal inhibitory concentration: 787 nM
The estimate for compound 4 lay 1.1-fold (0.06 log units) above the measured number; low and high end bracket the measured number.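

In this assay, putting 2-methylprop-1-en-1-yl in place of 1-chloroethenyl on the carbonyl carbon of the amide, now on the core of compound 3, gives a 1.1-fold lower number from compound 3 to compound 4 (0.05 log units; within the scatter), a step as flat as the one on the core of compound 1. Set side by side, the two steps show that this change carries from one core to the other in this series with no difference that the read-out can resolve: the same change on two cores in this assay, a 1.0-fold higher number (0.02 log units; within the scatter) from compound 1 to compound 2 and a 1.1-fold lower number (0.05 log units; within the scatter) from compound 3 to compound 4, 1.2-fold (0.07 log units) apart, within the scatter of two such steps

Going by these compounds alone, this agreement rests on only two cores and on two steps that are both flat; it shows that the read-out does not tell these two amides apart on either core, but it does not show that the step would stay flat on a further core, or that the two groups are equivalent in anything other than this cell read-out.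

Still open, from the compounds shown here alone, is whether a plain ethenyl amide, or an amide bearing a longer chain that ends in an amine, would sit at the same level on these two cores. Also open, going by these compounds, is how the separate parts of the difference between the core of compound 1 and the core of compound 3 each bear on the read-out.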